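A few compounds are considered here, and "the series" means these few. Any claim that something is new, unique, unknown or untested is made for them only; others in the source may bear on it.

Working notes on the series, read in a toxicity assay on CCRF-CEM cells (Homo sapiens) for cytotoxicity; a lower number here means that less compound is tolerated, a higher number that more compound is tolerated. Compound 1 `Cc1cccc2c1nc(-c1c(F)cccc1F)n2Cc1c(F)cccc1F` carries methyl on an aromatic carbon of the shared core, while compound 2 `CC(=O)N(C)c1cccc2c1nc(-c1c(F)cccc1F)n2Cc1c(F)cccc1F` carries acetyl(methyl)amino and compound 3 `CN(C)c1cccc2c1nc(-c1c(F)cccc1F)n2Cc1c(F)cccc1F` carries dimethylamino at that place. Compound 1 gives > 100 uM, which is a limit of the assay. Compound 2 gives > 100 uM, again a limit. Compound 3 gives > 100 uM, also a limit, so it stands without a number of its own. The whole set is summed up as the limit of > 100 uM in this assay, at which 3 of the 3 values shown sit.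

Compound 4 `NC(=O)c1cccc2c1nc(-c1c(F)cccc1F)n2Cc1c(F)cccc1F` is the next step, with carbamoyl in place of dimethylamino on an aromatic carbon. Three measured steps change the group at this place: a step that the two limits leave unreadable from compound 1 to compound 2, a step that the two limits leave unreadable from compound 1 to compound 3 and a step that the two limits leave unreadable from compound 2 to compound 3. None of them has a readable size or direction, so they only show that all three groups end at the same limit. No step beyond the scatter is therefore expected in this assay, and no direction can be assigned. The expected change is a number no higher from compound 3 to compound 4 (the limit leaves the size open), and a limit is the likeliest report. For compound 4 the estimate is 100 uM, with an expected range of 40 uM to 200 uM.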

Compound 4, half-maximal toxic concentration: > 100 uM
Compound 4: no number, only a limit (the forecaster's own chance of this, stated with the estimate: 85%); the middle value lies on the limit itself.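

In this assay, within the data shown here, compound 4 gives > 100 uM, which is a limit of the assay, so no step from compound 1, compound 2 or compound 3 to compound 4 can be read. The compounds shown leave open at what concentration any of them turns toxic and whether the groups at this place differ at all, as the whole set stands at one value: the limit of > 100 uM in this assay, at which 4 of the 4 values shown sit.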